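This account rests on a few compounds, and the source may have more. Where it says the series, first, only, none or still open, it means among the compounds named here.

Compound 1 `COC1=C(C)C(=O)/C(=C(O)/C=C/c2ccc(O)cc2)C(=O)C1(C)C`: < 4 ug/mL (a limit)
Compound 2 `COC1=C(C)C(=O)/C(=C(O)/C=C/c2ccccc2C)C(=O)C1(C)C`: < 4 ug/mL (a limit)
Compound 3 `COC1=C(C)C(=O)/C(=C(O)/C=C/c2cccs2)C(=O)C1(C)C`: < 4 ug/mL (a limit)

All three were tested in a functional assay on HUVEC cells (Homo sapiens); a lower number here means that less compound is needed, a higher number that more compound is needed for the effect. Compound 3 stands only at a limit, < 4 ug/mL, and has no number of its own. Compound 4 `COC1=C(C)C(=O)/C(=C(O)/C=C/c2nccs2)C(=O)C1(C)C` carries 1,3-thiazol-2-yl in place of thiophen-2-yl on a double-bonded chain carbon bound to a double-bonded chain carbon. The measured steps bearing on this are a step that the two limits leave unreadable from compound 1 to compound 3, a step that the two limits leave unreadable from compound 2 to compound 3 and a step that the two limits leave unreadable from compound 1 to compound 2. The three compounds share one reading, (the limit of < 4 ug/mL in this assay, at which 3 of the 3 values shown sit). No size or direction follows from these steps, so no step beyond the scatter is expected in this assay. The expected change is a step that the limit leaves unreadable from compound 3 to compound 4. Compound 4 is estimated at 2 ug/mL, with an expected range from 0.5 ug/mL to 5 ug/mL.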

Compound 4, concentration for half-maximal effect: < 4 ug/mL
Compound 4 ended at the assay's limit (the forecaster's own chance of this, stated with the estimate: 75%); the middle value lies beyond the limit too.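

Compound 4 also sits at a limit, so no step can be read between it and compound 1, compound 2 or compound 3 in this assay: the limit of < 4 ug/mL in this assay, at which 4 of the 4 values shown sit.

The compounds shown leave open whether 1,3-thiazol-2-yl and thiophen-2-yl differ at all in this assay.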